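Methoxy for ethynyl: working notes on compound 4

The source may report more compounds than this note shows. Statements on the series, on what has been measured and on what is new or still open speak of the compounds shown alone.

Readings in a functional assay on A549 cells (Homo sapiens) for cytotoxicity, read by MTT assay, with a stated time of 72 h (a lower number here means a stronger inhibitor, a higher number a weaker inhibitor), for the series:
- compound 1 `Cc1oc2ncnc(Nc3cccc(Br)c3)c2c1C(=O)O` gives 43000 nM as a number
- compound 2 `C#Cc1cccc(Nc2ncnc3oc(C)c(C(=O)OCC)c23)c1` gives > 1000000 nM as a limit
- compound 3 `Cc1oc2ncnc(Nc3cccc(Cl)c3)c2c1C(=O)NCCO` gives > 1000000 nM as a limit

Compound 2 reports only the limit > 1000000 nM and no number. That is its whole standing (the limit of > 1000000 nM in this assay, at which 2 of the 3 values shown sit).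

Compound 4 `CCOC(=O)c1c(C)oc2ncnc(Nc3cccc(OC)c3)c12` differs from compound 2 in one place (methoxy in place of ethynyl on an aromatic carbon), with 3-ethynylphenyl going to 3-methoxyphenyl. No measured step among these compounds isolates this change. In this assay a small step toward stronger inhibition is expected, or none beyond the scatter. The expected move runs an at least 2.5-fold lower number from compound 2 to compound 4 (0.39 log units; beyond the scatter) and starts from a limit. For compound 4 the estimated value is 400000 nM with an expected range from 50000 nM to 1000000 nM and a reading at the limit remains likely.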

Compound 4, half-maximal inhibitory concentration: > 1000000 nM
Compound 4 ended at the assay's limit (the forecaster's own chance of this, stated with the estimate: 55%); middle value at least 2.5-fold (0.39 log units) from the limit.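

Compound 2 and compound 4 both read as limits rather than numbers, so no step between them can be read: the limit of > 1000000 nM in this assay, at which 3 of the 4 values shown sit.
The compounds shown leave open whether methoxy in place of ethynyl changes the reading at all.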